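The source may report more compounds than this note shows. Statements on the series, on what has been measured and on what is new or still open speak of the compounds shown alone.

The account follows two hydrazide inhibitors and one untested analogue. Compound 1 `CCCCCCNNC(=O)c1ccc(-c2ccc(CNC(C)=O)cc2)cc1` is measured in an assay on isolated protein for inhibition of histone deacetylase 8 (Homo sapiens), read by fluorescence, with a stated time of 5 min (a higher number here means a weaker inhibitor, a lower number a stronger inhibitor), where compound 1 gives 36 nM. For the measured compounds named here, of the two numbers known, that of compound 1 is the highest: compound 2 `CCCCCCNNC(=O)c1cnc(N2CCN(Cc3c[nH]c4ccccc34)CC2)nc1` gives 5.9 nM in this assay, and the gap between the two values lies beyond the scatter. The untested compound 3 `CCCNNC(=O)c1ccc(-c2ccc(CNC(C)=O)cc2)cc1` differs from compound 1 in one place: hydrogen in place of propyl on a saturated chain carbon, three bonds along the chain from an amine nitrogen. Going by the values given here, no step between measured compounds is available to calibrate this change, so the expectation rests on the structural difference alone. Compound 3 is expected to be a weaker inhibitor than compound 1, and the estimated step of a 14-fold higher number from compound 1 to compound 3 (1.14 log units; beyond the scatter) is taken to be clearly beyond the scatter, towards a higher number. In this assay compound 3 is therefore estimated at 500 nM, with a likely range from 100 nM to 3000 nM.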

Compound 3, half-maximal inhibitory concentration: 700 nM
The estimate for compound 3 lay 1.4-fold (0.15 log units) below the measured number; low and high end bracket the measured number.
By their numbers in this assay, from the lowest: compound 2; then compound 1; then compound 3.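

In this assay, shortening the hexyl chain of compound 1 to the propyl chain of compound 3 gives a 19-fold higher number from compound 1 to compound 3 (1.29 log units; beyond the scatter), a large step from one change at a saturated chain carbon, three bonds along the chain from an amine nitrogen. The outer three carbons of the hexyl chain therefore matter greatly to the inhibition seen on this core, which the earlier pair could not show, as compound 1 and compound 2 differ in more than one place. Nothing available explains the size of this step.

The compounds shown leave open how the number changes with a butyl, a pentyl or a longer chain such as octyl. They also leave open what a hydroxyl or an amine at the end of the chain would do, and whether shortening the hexyl chain of compound 2 would give a step of similar size.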